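Swapping a Dimethylamino Group for a Larger Nitrogen-Rich Group

The compounds below may be only part of what the source reports. "The series", "measured", "known", "first", "only" and "open" are said of these compounds alone.

Of the compounds shown here, three sharing one core have been tested in an assay on cells for inhibition of Voltage-dependent T-type calcium channel subunit alpha-1H (Homo sapiens), read by FLIPR and calcium flux, with stated times of 600 s and 300 s; a higher number here means a weaker inhibitor, a lower number a stronger inhibitor. Compound 1 `CN(Cc1ccc(OCCCNC(=N)N)cc1)c1nc2ccc(Oc3cccc(C(F)(F)F)c3)cc2s1` gives 771000 nM. Compound 2 `N=C(N)NCCCOc1ccc(CNc2nc3ccc(Oc4ccc(O)cc4)cc3s2)cc1` gives 319000 nM. Compound 3 `CN(C)CCCOc1ccc(CNc2nc3ccc(Oc4cccc(C(F)(F)F)c4)cc3s2)cc1` gives 110000 nM, the lowest of the three numbers, and its gaps to compound 2 and to compound 1 both lie beyond the usual scatter, so compound 3 is the strongest inhibitor of the three, though still a weak one.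

Compound 4 `N=C(N)NCCCOc1ccc(CNc2nc3ccc(Oc4cccc(C(F)(F)F)c4)cc3s2)cc1` has not yet been measured. It differs from compound 3 in one place: a group of 4 heavy atoms (1 carbon, 3 nitrogen; no ring) in place of a group of 3 heavy atoms (2 carbon, 1 nitrogen; no ring), on a saturated chain carbon, three bonds along the chain from an oxygen on an aromatic ring The group that enters is the same one found in compound 2, and compound 1 carries a closely related group.

Within the data shown here, no measured pair here isolates exactly this change, so the expectation rests on the neighbours. The step of a 2.3-fold higher number from compound 3 to compound 4 (0.36 log units; beyond the scatter) is expected to go toward a higher number, of a size beyond the scatter, because compound 2 gives 319000 nM and compound 1 gives 771000 nM. Compound 4 is estimated at 250000 nM, within a range from 90000 nM to 700000 nM.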

Compound 4, half-maximal inhibitory concentration: 270000 nM
For compound 4 the middle estimate is 1.1-fold (0.03 log units) below the measured one, and the stated range covers the measured number.
By their numbers in this assay, from the lowest: compound 3; then compounds 4 and 2 (each within the scatter of the next); then compound 1.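

In this assay, the dimethylamino group on the saturated chain carbon can now be compared directly with the larger nitrogen-rich group, and the swap is a 2.5-fold higher number from compound 3 to compound 4 (0.39 log units; beyond the scatter), a modest loss of strength with the rest of the molecule unchanged. Compound 4 also links the other two compounds to this series: 3-(trifluoromethyl)phenyl in place of 4-hydroxyphenyl on an oxygen on an aromatic ring is a 1.2-fold lower number from compound 2 to compound 4 (0.07 log units; within the scatter), so that change shows no clear effect here. Hydrogen in place of methyl on a nitrogen on an aromatic ring is a 2.9-fold lower number from compound 1 to compound 4 (0.46 log units; beyond the scatter), a modest gain in strength.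

Nothing shown here gives a measured reason for any of these steps. As far as these compounds go, how a simple primary amine, or a longer chain carrying the dimethylamino group, would compare at this position remains open.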